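Changing the Halogenated Ring on the Amide Nitrogen

The compounds below may be only part of what the source reports. "The series", "measured", "known", "first", "only" and "open" are said of these compounds alone.

Three compounds built on one shared core, differing only in the aromatic ring attached to the amide-type nitrogen, have been tested in a functional assay on MGC-803 cells (Homo sapiens) for inhibition, read by MTT assay, with a stated time of 72 h; on this read-out higher numbers stand for weaker inhibition and lower numbers for stronger inhibition. Compound 1 `O=C(CSc1nc(Nc2ccccc2)c2ccccc2n1)Nc1ccccc1Br` gives 18600 nM in this assay. Compound 2 `O=C(CSc1nc(Nc2ccccc2)c2ccccc2n1)Nc1cccc(F)c1` gives 12700 nM, and compound 3 `O=C(CSc1nc(Nc2ccccc2)c2ccccc2n1)Nc1ccc(C(F)(F)F)cc1` gives 8670 nM. Compound 2 thus holds the middle of the three numbers, sitting within the scatter of both compound 1 and compound 3.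

Compound 4 `O=C(CSc1nc(Nc2ccccc2)c2ccccc2n1)Nc1ccc(Cl)cc1Cl` is not yet measured. The change from compound 2 is 2,4-dichlorophenyl in place of 3-fluorophenyl on an amide-type nitrogen.

Every step seen so far is of the same type, one halogen-bearing ring exchanged for another on this nitrogen: a 1.5-fold lower number from compound 1 to compound 2 (0.17 log units; within the scatter), a 1.5-fold lower number from compound 2 to compound 3 (0.17 log units; within the scatter), and a 2.1-fold lower number from compound 1 to compound 3 (0.33 log units; beyond the scatter). Among the measured compounds shown here, no measured compound carries a 2,4-dichlorophenyl group, so nothing speaks directly to it. The steps of this kind have been small, at most modest, and mostly within the scatter, so a similarly small movement is expected in this assay, with no confident direction.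

Compound 4 is therefore estimated to give about 10000 nM, between 4000 nM and 25000 nM. This expectation amounts to a 1.3-fold lower number from compound 2 to compound 4 (0.10 log units; within the scatter).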

Compound 4, half-maximal inhibitory concentration: 12300 nM
Compound 4: middle estimate off by 1.2-fold (0.09 log units), on the low side, and the stated range covers the measured number.
By their numbers in this assay, from the lowest: compounds 3, 4, 2 and 1 (each within the scatter of the next, the first and the last beyond it).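

Placing a 2,4-dichlorophenyl ring on the amide-type nitrogen in place of the 3-fluorophenyl ring leaves this assay essentially unmoved, with a 1.0-fold lower number from compound 2 to compound 4 (0.01 log units; within the scatter), even though the incoming ring carries two chlorine atoms instead of one fluorine atom. Against the other two rings the picture is similar, with a 1.4-fold higher number from compound 3 to compound 4 (0.15 log units; within the scatter) and a 1.5-fold lower number from compound 1 to compound 4 (0.18 log units; within the scatter), so the new ring falls within the scatter of all three earlier compounds and the only step beyond it remains a 2.1-fold lower number from compound 1 to compound 3 (0.33 log units; beyond the scatter). Nothing available explains why these differently substituted rings give such similar numbers.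

Every ring shown at this nitrogen is a phenyl ring bearing halogen or trifluoromethyl, so it remains open how the number would respond to a plain phenyl ring, or to a ring carrying an amine or a carboxylic acid. The rest of the shared core is identical in all four compounds, so these results also say nothing about what a change elsewhere, such as a longer chain in place of the existing one leading to the amide carbonyl, would do.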